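A few compounds are considered here, and "the series" means these few. Any claim that something is new, unique, unknown or untested is made for them only; others in the source may bear on it.

Values in an ADME assay on microsomes (Homo sapiens) for metabolic stability; a lower number here means slower removal, a higher number faster removal of the compound:
- compound 1 `Cc1cc(C(F)(F)F)c2cccc(OCc3c(Cl)ccc(S(=O)(=O)N4CCC(CCO)CC4)c3Cl)c2n1`: 367 mL/min/kg
- compound 2 `CNC(=O)[C@@H]1CCCN1S(=O)(=O)c1ccc(Cl)c(COc2cccc3c(-c4nccn4C)cc(C)nc23)c1Cl`: 117 mL/min/kg
- compound 3 `CNC(=O)[C@@H]1CCCN1S(=O)(=O)c1ccc(Cl)c(COc2cccc3c(OCc4ccccc4)cc(C)nc23)c1Cl`: 467 mL/min/kg

Compound 3 and compound 1 lie within the scatter of each other at the top of these three numbers, while compound 2 stands clearly apart from compound 3.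

The next compound to read is compound 4 `CNC(=O)[C@@H]1CCCN1S(=O)(=O)c1ccc(Cl)c(COc2cccc3c(-c4ccncc4)cc(C)nc23)c1Cl`. It carries pyridin-4-yl in place of benzyloxy on an aromatic carbon, opposite the ring nitrogen: pyridin-4-yl in place of benzyloxy on an aromatic carbon.

Going by the values given here, only one measured step bears on this change. Putting benzyloxy in place of 1-methyl-1H-imidazol-2-yl at the same place gave a 4.0-fold higher number from compound 2 to compound 3 (0.60 log units; beyond the scatter). Compound 4 also loses the benzyloxy group and gains an aromatic ring with a hetero atom, so it is expected to move back towards compound 2 at 117 mL/min/kg. Among the compounds with values here, no measured compound carries pyridin-4-yl, and this single pair is the whole basis for the direction, so the size remains uncertain.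

A lower number is expected in this assay, and the estimated step is a 2.7-fold lower number from compound 3 to compound 4 (0.44 log units; beyond the scatter). Compound 4 is estimated at 170 mL/min/kg, with an expected range of 85 mL/min/kg to 340 mL/min/kg.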

Compound 4, clearance: 217 mL/min/kg
For compound 4 the middle estimate is 1.3-fold (0.11 log units) below the measured one, within the range that was stated.
By their numbers in this assay, from the lowest: compounds 2, 4, 1 and 3 (each within the scatter of the next, the first and the last beyond it).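

In this assay, pyridin-4-yl in place of benzyloxy on the same aromatic carbon, opposite the ring nitrogen, gives a 2.2-fold lower number from compound 3 to compound 4 (0.33 log units; beyond the scatter), so a second group with a six-membered aromatic ring holding a hetero atom also stands apart from benzyloxy at this place. The two aromatic groups with hetero atoms cannot be told apart here, with a 1.9-fold higher number from compound 2 to compound 4 (0.27 log units; within the scatter), so among the three groups compared at this carbon, benzyloxy alone sits at the high end, and a six-membered ring serves as well as the 1-methyl-1H-imidazol-2-yl ring. No measurement at hand explains these differences between the groups.

Still open, going by these compounds, is whether the lower numbers need the hetero atom in the ring at all, which a plain phenyl group at this carbon would test, and whether a non-aromatic group such as an amine or a short alkyl chain would fall with compound 2 and compound 4 or with compound 3. On these data alone, compound 1 carries trifluoromethyl at this carbon but also differs in its sulfonamide part, so it gives no direct reading of that group, and whether the steps seen here hold with another sulfonamide also remains open.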